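This account rests on a few compounds, and the source may have more. Where it says the series, first, only, none or still open, it means among the compounds named here.

The compounds share a core carrying two dithiocarbamate arms and differ at two places on the fused ring system. Compound 1 `CN(C)C(=S)SCC(CSC(=S)N(C)C)C(=O)c1cnn2ccccc12` gives 31500 nM in a functional assay on NCI-H460 cells (Homo sapiens) for inhibition, read by MTT assay, with a stated time of 72 h; on this read-out higher numbers stand for weaker inhibition and lower numbers for stronger inhibition. Compound 2 `CN(C)C(=S)SCC(CSC(=S)N(C)C)C(=O)c1c(-c2ccccc2)nn2ccccc12` differs from it by phenyl in place of hydrogen on an aromatic carbon and gives 4090 nM in this assay, so that single change made a 7.7-fold lower number from compound 1 to compound 2 (0.89 log units; beyond the scatter). Compound 3 `CN(C)C(=S)SCC(CSC(=S)N(C)C)C(=O)c1cnn2ncccc12` carries a different core; how the two cores differ is not broken down here. In this assay compound 3 gives 4550 nM, a number that sits with that of compound 2 and well away from that of compound 1. Compound 4 `CN(C)C(=S)SCC(CSC(=S)N(C)C)C(=O)c1c(-c2ccccc2)nn2ncccc12` differs from compound 3 by phenyl in place of hydrogen on an aromatic carbon, at a place described in the same words as for the earlier pair, so it is the same change on the other core. For the measured compounds named here, because compound 1 to compound 2 showed a 7.7-fold lower number from compound 1 to compound 2 (0.89 log units; beyond the scatter), a step of similar direction is expected, though only one prior instance is known. Compound 4 is therefore estimated at 800 nM in this assay, spanning 250 nM to 2500 nM, which would mean a 5.7-fold lower number from compound 3 to compound 4 (0.75 log units; beyond the scatter) from compound 3.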

Compound 4, half-maximal inhibitory concentration: 1000 nM
Compound 4: middle estimate off by 1.3-fold (0.10 log units), on the low side; low and high end bracket the measured number.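

On the second core, phenyl in place of hydrogen on an aromatic carbon again lowers the number in this assay, with a 4.6-fold lower number from compound 3 to compound 4 (0.66 log units; beyond the scatter). Set beside the earlier step, the change carries over between these two cores, in direction and in size: the same change on two cores in this assay, a 7.7-fold lower number (0.89 log units; beyond the scatter) from compound 1 to compound 2 and a 4.6-fold lower number (0.66 log units; beyond the scatter) from compound 3 to compound 4, 1.7-fold (0.23 log units) apart, within the scatter of two such steps. For the compounds shown here, this rests on only two pairs of compounds in one cell assay, so it does not show that the step would hold on any other core, and it does not explain why phenyl lowers the number.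

The compounds shown leave open whether a phenyl ring is needed at all, or whether a smaller group on the same aromatic carbon, such as methyl, or a phenyl carrying fluorine or methoxy, would serve as well. They also leave open how the numbers would move if the dimethylamino ends of the two dithiocarbamate arms gave way to a cyclic amine such as morpholine.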